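From 3-bromophenyl to 4-bromophenyl

The source may hold more compounds than are shown below. What is called first, only, known or untested is meant among the compounds shown, and "the series" means these compounds.

Among the measured compounds shown here, in a functional assay on HepG2 cells (Homo sapiens) for antiproliferative activity, read by MTT assay, with a stated time of 48 h (a higher number here means a weaker inhibitor, a lower number a stronger inhibitor), compound 3 `CN1CCN(CC(=O)Nc2ccc3ncnc(Nc4cccc(Br)c4)c3c2)CC1` gives 25300 nM, the only actual number among the three measured compounds. Compound 1 `CN1CCN(CC(=O)Nc2ccc3ncnc(Nc4cccc(C(F)(F)F)c4)c3c2)CC1` reports only a limit, > 100000 nM. Compound 2 `CN1CCN(CC(=O)Nc2ccc3ncnc(Nc4ccc(Cl)cc4)c3c2)CC1`, which carries 4-chlorophenyl, also reports only a limit, > 100000 nM. Compound 4 `CN1CCN(CC(=O)Nc2ccc3ncnc(Nc4ccc(Br)cc4)c3c2)CC1` differs from compound 3 by 4-bromophenyl in place of 3-bromophenyl on a nitrogen on an aromatic ring, with 4-bromophenyl in place of 3-bromophenyl on a nitrogen on an aromatic ring. The closest measured change is an at least 3.9-fold lower number from compound 2 to compound 3 (0.59 log units; beyond the scatter), while an at least 3.9-fold lower number from compound 1 to compound 3 (0.59 log units; beyond the scatter), with bromo in place of trifluoromethyl, bears on it less directly. On the evidence of compound 2, a higher number is expected, with an estimated 2.4-fold higher number from compound 3 to compound 4 (0.38 log units; beyond the scatter). Compound 4 is estimated at 60000 nM, within a range of 20000 nM to 100000 nM, and it may also reach the limit.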

Compound 4, half-maximal inhibitory concentration: > 100000 nM
Compound 4 ended at the assay's limit; the forecaster's own chance of this, stated with the estimate: 45%; at least 1.6-fold (0.22 log units) between middle value and limit.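

Going from 3-bromophenyl to 4-bromophenyl, with the same atoms joined differently, gives an at least 3.9-fold higher number from compound 3 to compound 4 (0.59 log units; beyond the scatter) in this assay. Among the compounds shown here, the earlier steps all changed the substituent itself, whereas this one changes only where the bromo sits on the ring, and that alone is enough to lose the one measured number. The steps between compounds at the limit cannot be read, and the series is largely bounded by it: the limit of > 100000 nM in this assay, at which 3 of the 4 values shown sit.

Going by these compounds, whether the number of compound 3 depends on bromo itself stays open. A 3-chlorophenyl or 3-methoxyphenyl group on the same nitrogen would bear on this.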